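Fluorophenyl Replaces Benzyloxy on an Inactive Core

A few compounds are considered here, and "the series" means these few. Any claim that something is new, unique, unknown or untested is made for them only; others in the source may bear on it.

Measured so far in a functional assay on NALM-6 cells (Homo sapiens) for cytotoxicity, with a stated time of 72 h; on this read-out higher numbers stand for an effect only at larger amounts of compound and lower numbers for an effect already at smaller amounts:
Compound 1 `C=C[C@@](C)(/C=C/c1ccc(OCc2ccccc2)cc1)CCC=C(C)C` gives > 43400 nM, which is a limit of the assay.
Compound 2 `COc1ccc(/C=C/[C@@](C)(/C=C/c2ccc(O)c(/C=C/C(C)=O)c2)CCC=C(C)C)cc1` gives > 43400 nM, likewise a limit of the assay.

Compound 1 thus stands at the limit of > 43400 nM in this assay, at which 2 of the 2 values shown sit, and no number is known for it. Compound 3 `C=C[C@@](C)(/C=C/c1ccc(-c2cccc(F)c2)cc1)CCC=C(C)C` differs from compound 1 by 3-fluorophenyl in place of benzyloxy on an aromatic carbon. No measured step between related compounds exists in this assay, so nothing shown indicates that this change moves the read-out beyond the scatter in either direction. Compound 3 is expected to remain at the limit too, an estimated step of a number no higher from compound 1 to compound 3 (the limit leaves the size open) of about none. The estimate for compound 3 is 43400 nM, between 15000 nM and 120000 nM.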

Compound 3, half-maximal effective concentration: > 43400 nM
Compound 3 was reported as a limit; the forecaster's own chance of this, stated with the estimate: 80%; the middle value lies on the limit itself.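

No step can be read from compound 1 to compound 3, since both values are limits and not numbers: the limit of > 43400 nM in this assay, at which 3 of the 3 values shown sit.

The compounds shown leave open which change to the shared core, if any, would give a real number in this assay rather than a limit.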